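A few compounds are considered here, and "the series" means these few. Any claim that something is new, unique, unknown or untested is made for them only; others in the source may bear on it.

Compound 1, `COc1cc(-c2nnc3n2NC(c2cccs2)C(C(=O)c2ccc(C)cc2)S3)cc(OC)c1OC`: 28400 nM
Compound 2, `COc1cc(-c2nnc3n2NC(c2cccs2)C(C(=O)c2ccc(F)cc2)S3)cc(OC)c1OC`: 43700 nM
Compound 3, `COc1ccc(C(=O)C2Sc3nnc(-c4cc(OC)c(OC)c(OC)c4)n3NC2c2ccco2)cc1`: > 100000 nM

Of the compounds shown here, three have been measured in a functional assay on MCF7 cells (Homo sapiens) for cytotoxicity, read by MTT assay, with a stated time of 48 h; a higher number here means a weaker inhibitor, a lower number a stronger inhibitor. Within the data shown here, compound 1 gives 28400 nM and compound 2 gives 43700 nM; the step of a 1.5-fold higher number from compound 1 to compound 2 (0.19 log units; within the scatter) is the only measured step between compounds that differ in one place. For compound 3 only a limit of this assay is recorded, > 100000 nM, so compound 3 sits at the limit of > 100000 nM in this assay, at which 1 of the 3 values shown sits, and its place among the numbers cannot be fixed. Compound 4, `COc1ccc(C(=O)C2Sc3nnc(-c4cc(OC)c(OC)c(OC)c4)n3NC2c2cccs2)cc1`, differs from compound 3 by thiophen-2-yl in place of furan-2-yl on a saturated ring carbon. Among the measured compounds shown here, compound 1 and compound 2 also carry thiophen-2-yl on the saturated ring carbon of their shared core, but their aryl carbonyl groups differ from the (4-methoxyphenyl)carbonyl group of compound 4, and no measured step exchanges furan-2-yl for thiophen-2-yl, so nothing recorded bears directly on this change. Compound 4 is therefore expected to give a number rather than a limit, estimated at 40000 nM with a range of 15000 nM to 100000 nM, because compound 1 gives 28400 nM and compound 2 gives 43700 nM. This would mean an expected step of an at least 2.5-fold lower number from compound 3 to compound 4 (0.39 log units; beyond the scatter), read against a limit.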

Compound 4, half-maximal inhibitory concentration: 49500 nM
Compound 4: the middle estimate sits 1.2-fold (0.09 log units) below what was measured; measured number inside the range.
By their numbers in this assay, from the lowest: compounds 1, 2 and 4 (each within the scatter of the next). At a limit, above all of these: compound 3.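

Swapping furan-2-yl for thiophen-2-yl on the saturated ring carbon gives a first number with the (4-methoxyphenyl)carbonyl group in this assay (an at least 2.0-fold lower number from compound 3 to compound 4 (0.30 log units; that floor lies within the scatter)), though the size of this step stays unfixed. Methoxy on the aromatic carbon does not separate from fluoro (a 1.1-fold higher number from compound 2 to compound 4 (0.05 log units; within the scatter)) or from methyl (a 1.7-fold higher number from compound 1 to compound 4 (0.24 log units; within the scatter)), so all three groups give values within the scatter of one another with thiophen-2-yl in place. Compound 3 remains at a limit, not a number: the limit of > 100000 nM in this assay, at which 1 of the 4 values shown sits.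

From the compounds shown here alone, how far the furan-2-yl and thiophen-2-yl compounds truly lie apart remains open. Also open, going by these compounds, is whether an amine or a carboxylic acid on that aromatic carbon would separate from methoxy, fluoro and methyl.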